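Adding a methoxy group to compound 2

The source may hold more compounds than are shown below. What is called first, only, known or untested is meant among the compounds shown, and "the series" means these compounds.

In an ADME assay on MT4 cells (Homo sapiens) for cytotoxicity, read by MTT assay, with a stated time of 4 days (on this read-out lower numbers stand for higher toxicity in this test and higher numbers for lower toxicity in this test), the measured compounds stand as follows
Compound 1 `CC(=O)Nc1ccc2oc(-c3ccccc3)cc(=O)c2c1` gives 184000 nM
Compound 2 `CC(=O)Nc1ccc2oc(-c3ccccc3)c(O)c(=O)c2c1` gives 64700 nM

Compound 2 stands lowest of the two, at 64700 nM so far. Compound 3 `COc1ccccc1-c1oc2ccc(NC(C)=O)cc2c(=O)c1O` differs from it by methoxy in place of hydrogen on an aromatic carbon in the form of methoxy in place of hydrogen on an aromatic carbon. Among the measured compounds shown here, the one measured step is modest, a 2.8-fold lower number from compound 1 to compound 2 (0.45 log units; beyond the scatter) and it involved hydroxy rather than methoxy, so it bears only loosely here. No step beyond the scatter is therefore expected in this assay and no direction can be argued. The expected change is a 1.1-fold lower number from compound 2 to compound 3 (0.03 log units; within the scatter) at most in size. Compound 3 is estimated at 60000 nM with an expected range from 22000 nM to 170000 nM in this test.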

Compound 3, half-maximal cytotoxic concentration: 385000 nM
Compound 3: the middle estimate sits 6.4-fold (0.81 log units) below what was measured; measured number above the stated range.
By their numbers in this assay, from the lowest: compound 2; then compound 1; then compound 3.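

The change from phenyl to 2-methoxyphenyl gives a 6.0-fold higher number from compound 2 to compound 3 (0.77 log units; beyond the scatter) in this assay, so a substituent on this six-membered aromatic ring of carbon only, ortho to a large group, does shift the read-out. The shift is towards lower toxicity in this test, opposite in direction to the hydroxy step, a 2.8-fold lower number from compound 1 to compound 2 (0.45 log units; beyond the scatter). Nothing available explains this reversal. From the compounds shown here alone, it remains open whether a larger ethoxy group or an amine at this place would move the number the same way, and how far methoxy itself depends on this placement.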